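Two measured analogues and one ethoxy variant awaiting measurement

The source may report more compounds than this note shows. Statements on the series, on what has been measured and on what is new or still open speak of the compounds shown alone.

Measured so far:
compound 1 `CC(C)=CCOc1c(C)c(C)c2c(c1C)CCC(C)(COc1ccc(/C=C3\SC(=O)NC3=O)cc1C)O2`: 89%
compound 2 `CC(C)=CCOc1c(C)c(C)c2c(c1C)CCC(C)(COc1ccc(/C=C3\SC(=O)NC3=O)cc1-c1ccc(F)cc1)O2`: 87%

Both numbers come from a functional assay on MCF7 cells (Homo sapiens), tested at 2.5 uM; a higher number here means a weaker effect of the compound at the concentration tested, a lower number a stronger effect. Among the measured compounds shown here, compound 2 stands with the lower of the two numbers, but the one step so far, a number 2 percentage points lower from compound 1 to compound 2 (within the scatter), is within the scatter, so the two compounds are not distinguished by it; only compound 1 serves as a comparison.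

Compound 3 `CCOc1cc(/C=C2\SC(=O)NC2=O)ccc1OCC1(C)CCc2c(C)c(OCC=C(C)C)c(C)c(C)c2O1` is not yet measured. It differs from compound 2 in one place: ethoxy in place of 4-fluorophenyl on an aromatic carbon

For the measured compounds named here, no measured step changes this same position in this same way, so the only guidance is the step from compound 1 to compound 2, which was within the scatter. On that basis no step beyond the scatter is expected for a number 1 percentage points higher from compound 2 to compound 3 (within the scatter). Compound 3 is therefore estimated at 88% in this assay, within a range from 70% to 100%.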

Compound 3, a percentage reported as activity, at one concentration (the size of the read-out at that concentration, not a potency): 107%
The estimate for compound 3 lay 19 percentage points below the measured number; the whole stated range lies below it.
By their numbers in this assay, from the lowest: compounds 2 and 1 (each within the scatter of the next); then compound 3.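

This position is not indifferent to the group it carries in this assay: methyl and 4-fluorophenyl could not be told apart there, but ethoxy brings a number 20 percentage points higher from compound 2 to compound 3 (beyond the scatter) and a number 18 percentage points higher from compound 1 to compound 3 (beyond the scatter), a weaker effect at the concentration tested. Size of the substituent alone does not order these results, since the two groups within the scatter of each other both differ from ethoxy, which, unlike 4-fluorophenyl, carries an oxygen and a hydrogen-bond acceptor. No supporting data bear on the reason for this rise.

From the compounds shown here alone, it remains open whether the oxygen attached to the aromatic carbon or the ethyl part goes with the higher number. A hydroxyl, a methoxy or a longer alkoxy chain such as propoxy would separate these, and an amine at the same place would test another heteroatom there.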